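The source may report more compounds than this note shows. Statements on the series, on what has been measured and on what is new or still open speak of the compounds shown alone.

Values in a functional assay on A2780 cells (Homo sapiens) for inhibition, read by trypan blue exclusion, with a stated time of 72 h; on this read-out lower numbers stand for stronger inhibition of growth and higher numbers for weaker inhibition of growth:
- compound 1 `CCCn1c(-c2ccc(O)cc2)c(C)c2cc(O)ccc21`: 2300 nM
- compound 2 `Cc1c(-c2ccc(O)cc2)n(CCCCOc2ccccc2)c2ccc(O)cc12`: 2000 nM
- compound 3 `Cc1c(-c2ccc(O)c(O)c2)n(CCCOc2ccccc2)c2ccc(O)cc12`: 7400 nM

Compound 3 has the highest of the three numbers, and compound 1 and compound 2 both lie lower, beyond the scatter. The next compound to be read is compound 4 `Cc1c(-c2ccc(O)cc2)n(CCCOc2ccccc2)c2ccc(O)cc12`, which keeps the chain of compound 3 and changes the aryl group from 3,4-dihydroxyphenyl to 4-hydroxyphenyl, with hydrogen in place of hydroxy on an aromatic carbon.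

Among the compounds with values here, no measured step makes this change directly, so the evidence is indirect. Within the data shown here, the only measured step, a 1.2-fold lower number from compound 1 to compound 2 (0.06 log units; within the scatter), alters the chain and not the aryl group. It shows that the two compounds carrying 4-hydroxyphenyl cannot be told apart in this assay despite their different chains. Compound 4 carries the same group, so its number is expected to fall near theirs, with compound 1 at 2300 nM and compound 2 at 2000 nM. That implies a drop from the number of compound 3, meaning stronger inhibition of growth. The estimated step is a 3.4-fold lower number from compound 3 to compound 4 (0.53 log units; beyond the scatter). The chain of compound 3 has not been measured with 4-hydroxyphenyl, which keeps the range wide. Compound 4 is expected at 2200 nM, with an estimated range of 1000 nM to 5000 nM.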

Compound 4, concentration for 50% growth inhibition: 2200 nM
The estimate for compound 4 equals the measured number at the digits printed; the range from low to high includes it.
By their numbers in this assay, from the lowest: compounds 2, 4 and 1 (each within the scatter of the next); then compound 3.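

In this assay, within the data shown here, going from 3,4-dihydroxyphenyl to 4-hydroxyphenyl on an unchanged chain gives the first direct reading at this aromatic carbon (a 3.4-fold lower number from compound 3 to compound 4 (0.53 log units; beyond the scatter)), so on this chain the hydroxy that is ortho to a hydroxy group goes with weaker inhibition of growth, and hydrogen at that carbon recovers the level of the other 4-hydroxyphenyl compounds. With 4-hydroxyphenyl held fixed, the chain changes stay flat (a 1.1-fold higher number from compound 2 to compound 4 (0.04 log units; within the scatter); a 1.0-fold lower number from compound 1 to compound 4 (0.02 log units; within the scatter)), so among these four compounds the aryl change is the only single change with a step beyond the scatter, and the propyl, phenoxypropyl and phenoxybutyl chains cannot be told apart. No measurement at hand gives a reason for the effect of this hydroxy.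

Open, from the compounds shown here alone, is whether the same step appears on other chains, and what a methoxy group or a fluorine atom at this aromatic carbon would give in place of hydroxy or hydrogen. Also open, going by these compounds, is whether the flat chain response holds for a chain ending in an amine or a carboxylic acid.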